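This account rests on a few compounds, and the source may have more. Where it says the series, first, only, none or still open, it means among the compounds named here.

Measured compounds in a functional assay on SK-OV-3 cells (Homo sapiens) for cytotoxicity, read by sulforhodamine B assay, with a stated time of 48 h, tested at 10 uM; on this read-out higher numbers stand for a weaker effect at the one concentration tested and lower numbers for a stronger effect:
compound 1, `COc1cc(C)cc(-c2c(-c3ccnc(-c4ccc(C(C)=O)cc4)c3)cnn2CC#N)c1`, 27%;
compound 2, `Cc1cc(O)cc(-c2nn(CC#N)cc2-c2ccnc(-c3ccc(Oc4ccccc4)cc3)c2)c1`, -99%;
compound 3, `Cc1cc(O)cc(-c2nn(CC#N)cc2-c2ccnc(-c3ccc(N(C)C)cc3)c2)c1`, -38%.

Compound 1 stands highest of the three numbers in this assay; compound 3 is nearest, compound 2 furthest, both beyond the scatter. Compound 4 is `COc1cc(C)cc(-c2c(-c3ccnc(-c4ccc(N(C)C)cc4)c3)cnn2CC#N)c1`; against compound 1 the change is dimethylamino in place of acetyl on an aromatic carbon. Within the data shown here, no measured step exchanges acetyl. Among the measured compounds shown here, the only step that bears on it is a number 61 percentage points higher from compound 2 to compound 3 (beyond the scatter), which puts dimethylamino on the same aromatic carbon as in compound 4 and moved the number upward by a large margin. On that basis, for compound 4 a step upward of moderate size is expected in this assay, a number 18 percentage points higher from compound 1 to compound 4 (beyond the scatter), with wide uncertainty as the leaving group differs. Compound 4 is estimated at 45%, range 10% to 80%.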

Compound 4, a percentage reported as activity, at one concentration (the size of the read-out at that concentration, not a potency): 26%
The estimate for compound 4 lay 19 percentage points above the measured number, and the stated range covers the measured number.
By their numbers in this assay, from the lowest: compound 2; then compound 3; then compounds 4 and 1 (each within the scatter of the next).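

In this assay, going from 4-acetylphenyl to 4-(dimethylamino)phenyl gives a number 1 percentage points lower from compound 1 to compound 4 (within the scatter) and so does not separate acetyl from dimethylamino at this position, para to a large group. Entry of dimethylamino therefore carries no fixed upward step: the large a number 61 percentage points higher from compound 2 to compound 3 (beyond the scatter) came with phenoxy leaving, whereas with acetyl leaving the two numbers lie within the scatter. Nothing on hand accounts for this contrast between the two exchanges.

Open, going by these compounds, is whether a carboxylic acid or a primary amine at this position would separate from acetyl and dimethylamino. Also open, on these data alone, is how phenoxy behaves on the core of compound 1.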